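This account rests on a few compounds, and the source may have more. Where it says the series, first, only, none or still open, it means among the compounds named here.

The series shares one core. Compound 2 `Cc1cc(NC(=O)Nc2ccc(N)cc2)c2ccccc2n1` stands highest of the three measured compounds: in a physicochemical assay for solubility, at pH 7.4 (on this read-out lower numbers stand for lower solubility and higher numbers for higher solubility), compound 2 gives 18500 nM, while compound 1 `Cc1cc(NC(=O)Nc2ncccc2C)c2ccccc2n1` gives 1300 nM and compound 3 `Cc1cc(NC(=O)Nc2cccc(Cl)c2)c2ccccc2n1` gives 800 nM. Both of the others sit far below compound 2, as the steps show: a 14-fold higher number from compound 1 to compound 2 (1.15 log units; beyond the scatter) and a 23-fold lower number from compound 2 to compound 3 (1.36 log units; beyond the scatter). Compound 1 and compound 3 are close to each other, with a 1.6-fold lower number from compound 1 to compound 3 (0.21 log units; within the scatter).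

Compound 4 `COC(=O)c1ccc(NC(=O)Nc2cc(C)nc3ccccc23)cc1` has not been measured. It differs from compound 2 in one place: methoxycarbonyl in place of amino on an aromatic carbon. The two measured steps that bear on this change are those in which the 4-aminophenyl group is exchanged, a 14-fold higher number from compound 1 to compound 2 (1.15 log units; beyond the scatter) and a 23-fold lower number from compound 2 to compound 3 (1.36 log units; beyond the scatter); both were large, and both place the 4-aminophenyl compound at the top. The exchange of the amino group for methoxycarbonyl is expected to fall on the same side, as a large step down, a 19-fold lower number from compound 2 to compound 4 (1.27 log units; beyond the scatter). Compound 4 is accordingly expected to give about 1000 nM in this assay, within a range of 300 nM to 4000 nM.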

Compound 4, solubility: 1200 nM
The estimate for compound 4 lay 1.2-fold (0.08 log units) below the measured number; the range from low to high includes it.
By their numbers in this assay, from the lowest: compounds 3, 4 and 1 (each within the scatter of the next); then compound 2.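

Holding the phenyl ring and the place fixed, on an aromatic carbon para to a large group, methoxycarbonyl in place of amino gives a 15-fold lower number from compound 2 to compound 4 (1.19 log units; beyond the scatter) in this assay, so the high number of compound 2 is tied to the amino group itself and not to the phenyl ring that carries it, which the earlier steps, each exchanging a whole aryl group, could not separate. This single step cannot tell the larger entering group apart from the hydrogen-bond donor that leaves with amino. Nothing measured on hand gives a cause for this step.

Open, from the compounds shown here alone, is whether a dimethylamino group at this place keeps the number near that of compound 2. Equally open, going by these compounds, is whether a carboxylic acid or a methyl ether there falls as far as compound 4.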